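Working notes on two measured compounds and one to follow

The source may hold more compounds than are shown below. What is called first, only, known or untested is meant among the compounds shown, and "the series" means these compounds.

Measured in a functional assay on the whole organism (Tail, strain ICR) with Mus musculus as the target, in the tail flick test, with a stated time of 60 min, at a dose of 25 umol/kg by the oral route; on this read-out lower numbers stand for a weaker effect and higher numbers for a stronger effect at the one dose given:
- compound 1 `NC(=O)C[C@H](NC(=O)CN(c1ncnc2c1ncn2C1CCCCO1)C1CC1)C(=O)OCc1ccccc1`: 30.5%
- compound 2 `C[C@H](NC(=O)CN(c1ncnc2c1ncn2C1CCCCO1)C1CC1)C(=O)OCc1ccccc1`: 53%

Going by the values given here, compound 2 holds the higher of the two numbers in this assay; the only other measured compound is compound 1, and the step is a number 22.5 percentage points higher from compound 1 to compound 2 (beyond the scatter), beyond the scatter. Among the compounds with values here, that single step is the whole record of the series so far, and it concerns only the removal of a carbamoyl group at the same position that is now varied.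

Compound 3 `CC(C)C[C@H](NC(=O)CN(c1ncnc2c1ncn2C1CCCCO1)C1CC1)C(=O)OCc1ccccc1` differs from compound 2 by isopropyl in place of hydrogen on a saturated chain carbon, two bonds along the chain from an amide-type nitrogen and a carbonyl carbon. Within the data shown here, no measured pair covers an entering isopropyl at this place. Among the measured compounds shown here, the one step that bears on the position, a number 22.5 percentage points higher from compound 1 to compound 2 (beyond the scatter), shows that a group with hydrogen-bond donors and acceptors there gave the lower number, whereas the group entering here counts none of either. With only that to go on, the change in this assay is expected to be small: a number 2 percentage points higher from compound 2 to compound 3 (within the scatter), not beyond the scatter. Compound 3 is therefore estimated at 55%, in the range 30% to 80%.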

Compound 3, a percentage reported as activity, at one dose (the size of the read-out at that dose, not a potency): 34.2%
Estimate against measurement, compound 3: 20.8 percentage points above; low and high end bracket the measured number.
By their numbers in this assay, from the lowest: compounds 1 and 3 (each within the scatter of the next); then compound 2.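

In this assay, isopropyl in place of hydrogen at this position, on a saturated chain carbon, two bonds along the chain from an amide-type nitrogen and a carbonyl carbon, gives a number 18.8 percentage points lower from compound 2 to compound 3 (beyond the scatter); read one bond further out, this is methyl to isobutyl. The lower number at this position therefore no longer belongs to carbamoyl alone: isopropyl, with 0 hydrogen-bond donors and 0 hydrogen-bond acceptors, gives a number 3.7 percentage points higher from compound 1 to compound 3 (within the scatter), so the two groups cannot be told apart in this read-out and only compound 2 stands clear of both. Nothing available explains why either group gives the lower number at this position.

Two groups that differ this much in their counts of donors and acceptors leave open what the number at this position follows, and ethyl or a straight propyl chain would show whether the number falls gradually or at once as the chain grows from methyl to isobutyl. Going by these compounds, a carboxylic acid, an amine or a phenyl group at the same place also remains open, as does whether any group there can reach or pass the number of compound 2 at this one dose and time.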